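This account rests on a few compounds, and the source may have more. Where it says the series, first, only, none or still open, it means among the compounds named here.

Working notes on the series, read in an ADME assay on MT4 cells (Homo sapiens) for cytotoxicity, read by MTT assay, with a stated time of 96 h; on this read-out higher numbers stand for lower toxicity in this test and lower numbers for higher toxicity in this test. Compound 3 `CCC(=O)Oc1ccc2c(C)cc(=O)oc2c1Cc1c(-c2ccccc2)[nH]c2ccccc12` carries a methyl on its core; in this assay compound 3 gives 38000 nM. Compound 2 `CCC(=O)Oc1ccc2ccc(=O)oc2c1Cc1c(-c2ccccc2)[nH]c2ccccc12` differs from compound 3 in one place only: hydrogen in place of methyl on an aromatic carbon. The value of compound 2 in this assay, > 100000 nM, is a limit of the assay and not a number. The measured step is therefore an at least 2.6-fold higher number from compound 3 to compound 2 (0.42 log units; beyond the scatter), and it is read against (the limit of > 100000 nM in this assay, at which 2 of the 3 values shown sit).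

Compound 1 `Cc1cc(=O)oc2c(CN3CCc4ccccc4C3)c(O)ccc12` is built on a different core; the difference between the two cores is not broken down here. The value of compound 1 in this assay, > 100000 nM, is likewise a limit of the assay. Compound 4 `O=c1ccc2ccc(O)c(CN3CCc4ccccc4C3)c2o1` has not yet been measured in this assay. It stands to compound 1 as compound 2 stands to compound 3: hydrogen in place of methyl on an aromatic carbon. The description of the place is the same word for word in both pairs, so this is taken as the same change, made a second time.

For compound 4 the expected step is a step that the limit leaves unreadable from compound 1 to compound 4, set beside the measured step of an at least 2.6-fold higher number from compound 3 to compound 2 (0.42 log units; beyond the scatter). This expectation rests on compound 1 already standing at the limit of > 100000 nM in this assay, at which 2 of the 3 values shown sit, so that a change of the same direction can hardly show as a number. Compound 4 is expected to give about 150000 nM in this assay, estimated to lie between 100000 nM and 300000 nM, most likely reported as a limit again.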

Compound 4, half-maximal cytotoxic concentration: > 100000 nM
Compound 4 was reported as a limit; the forecaster's own chance of this, stated with the estimate: 85%; the middle value does not contradict the limit.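

In this assay compound 4 gives > 100000 nM, which is a limit of the assay. Compound 1 gives > 100000 nM, likewise a limit, so no step between compound 1 and compound 4 can be read: the limit of > 100000 nM in this assay, at which 3 of the 4 values shown sit.

The compounds shown leave open whether hydrogen in place of methyl on an aromatic carbon changes this read-out at all on the core of compound 1, as it does between compound 3 and compound 2.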